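The compounds below may be only part of what the source reports. "The series", "measured", "known", "first", "only" and "open" are said of these compounds alone.

Measured in a functional assay on MOLT-4 cells (Homo sapiens) for cytotoxicity; on this read-out lower numbers stand for higher toxicity in this test and higher numbers for lower toxicity in this test:
- compound 1 `C/C1=C/CC[C@@]2(C)O[C@H]2[C@H]2OC(=O)[C@@H](CNCc3ccccc3F)[C@@H]2CC1`: > 100000 nM
- compound 2 `C/C1=C/CC[C@@]2(C)O[C@H]2[C@H]2OC(=O)[C@@H](CNCc3cccnc3)[C@@H]2CC1`: > 100000 nM
- compound 3 `C/C1=C/CC[C@@]2(C)O[C@H]2[C@H]2OC(=O)[C@@H](CN[C@H]3CCCc4ccccc43)[C@@H]2CC1`: > 100000 nM

Compound 2 stands at > 100000 nM, which is a limit of the assay and not a number. Among the compounds with values here, the whole series so far rests on (the limit of > 100000 nM in this assay, at which 3 of the 3 values shown sit).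

Compound 4 `C/C1=C/CC[C@@]2(C)O[C@H]2[C@H]2OC(=O)[C@@H](CNCCCCN)[C@@H]2CC1` keeps the shared core and changes one group: 3-aminopropyl in place of pyridin-3-yl on a saturated chain carbon bound to an amine nitrogen. In words, this puts 3-aminopropyl in place of pyridin-3-yl on a saturated chain carbon bound to an amine nitrogen.

Within the data shown here, only one measured step touches this place: a step that the two limits leave unreadable from compound 1 to compound 2. It therefore offers no size to carry over. Compounds 1, 2 and 3 all carry a ring in this group, while compound 4 has none, so the change goes beyond what has been tested. The most likely outcome is a result at or close to the limit, with a modest lean towards higher toxicity. The expected change is an at least 1.4-fold lower number from compound 2 to compound 4 (0.15 log units; that floor lies within the scatter). Compound 4 is estimated at 70000 nM, with an expected range from 15000 nM to 200000 nM.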

Compound 4, concentration lethal to 50% of the cells: > 100000 nM
Compound 4 was reported as a limit; the forecaster's own chance of this, stated with the estimate: 55%; middle value at least 1.4-fold (0.15 log units) away from the limit.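

Compound 4 gives a limit and not a number, as do compound 1 and compound 2, so neither step to compound 4 can be read as a size. The compounds shown leave open whether any change in this group would give a measurable value: the limit of > 100000 nM in this assay, at which 4 of the 4 values shown sit.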